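A few compounds are considered here, and "the series" means these few. Any claim that something is new, unique, unknown or untested is made for them only; others in the source may bear on it.

Of the compounds shown here, three share an amide-linked acid core and have been measured in an assay on isolated protein for agonist activity at Bile acid receptor (Homo sapiens), read by TR-FRET, with a stated time of 3 h, in the absence of a further agent; on this read-out higher numbers stand for an effect only at larger amounts of compound and lower numbers for an effect already at smaller amounts. Compound 1, `O=C(O)c1cccc(NC(=O)c2cccc(OCC3CC3)c2)c1`, gives 1260 nM in this assay. Compound 2, `O=C(O)c1cccc(NC(=O)c2cccc(OCc3ccccc3)c2)c1`, gives 1160 nM. The change from compound 1 to compound 2 is phenyl in place of cyclopropyl on a saturated chain carbon bound to an oxygen on an aromatic ring, and the step it made was a 1.1-fold lower number from compound 1 to compound 2 (0.04 log units; within the scatter). Compound 3, `O=C(O)c1cccc(NC(=O)c2cccc(-c3cccc(OCC4CC4)c3)c2)c1`, gives 206 nM in this assay, the lowest of the three numbers, and its gaps to compound 1 and to compound 2 both lie beyond the usual scatter. The difference between the core of compound 3 and the core of compound 1 is not broken down here.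

Compound 4, `O=C(O)c1cccc(NC(=O)c2cccc(-c3cccc(OCc4ccccc4)c3)c2)c1`, has not yet been measured. It differs from compound 3 by phenyl in place of cyclopropyl on a saturated chain carbon bound to an oxygen on an aromatic ring, the same change that led from compound 1 to compound 2. Because that earlier step was a 1.1-fold lower number from compound 1 to compound 2 (0.04 log units; within the scatter), the step from compound 3 to compound 4 is expected to be about a 1.0-fold lower number from compound 3 to compound 4 (0.01 log units; within the scatter), meaning roughly no change. The estimate for compound 4 in this assay is 200 nM, with a likely range from 100 nM to 400 nM.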

Compound 4, half-maximal effective concentration: 189 nM
Beside the measured number, compound 4's estimate is 1.1-fold (0.02 log units) above it; the range from low to high includes it.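

Phenyl in place of cyclopropyl also leaves the number within the usual scatter on the core of compound 3: in this assay, the result is a 1.1-fold lower number from compound 3 to compound 4 (0.04 log units; within the scatter). Set beside the earlier step, the two results agree: the same change on two cores in this assay, a 1.1-fold lower number (0.04 log units; within the scatter) from compound 1 to compound 2 and a 1.1-fold lower number (0.04 log units; within the scatter) from compound 3 to compound 4, 1.0-fold (0.00 log units) apart, within the scatter of two such steps. So, on these two cores, cyclopropylmethoxy and benzyloxy give matching results, and the swap carries over from one core to the other, but two cores are only two cases, and a change that barely moves the number on either is a mild test. It does not show that the swap would behave the same way on a further core, or that a change with a large step would carry over as neatly.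

The compounds shown leave open what happens when an amine, a carboxylic acid or a longer chain takes the place of cyclopropylmethyl or benzyl. They also leave open whether any such group would behave alike on both cores.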